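Swapping a Benzyl Amide for a Pyridinylmethyl Carbamate

The source may hold more compounds than are shown below. What is called first, only, known or untested is meant among the compounds shown, and "the series" means these compounds.

Measured so far:
compound 1, `Cc1cc(C(=O)NCc2ccccc2)nn1Cc1cc(Cl)ccc1OCc1ccccc1`, > 3.7
compound 2, `Cc1cc(NC(=O)C2CCCC2)nn1Cc1cc(Cl)ccc1OCC(C)C`, > 3.7

In a physicochemical assay for lipophilicity, at pH 7.4 (a lower number here means a more polar compound, a higher number a more lipophilic compound), compound 1 gives > 3.7, which is a limit of the assay rather than a number. Compound 2 also gives only a limit, > 3.7. Compound 1 thus stands at the limit of > 3.7 in this assay, at which 2 of the 2 values shown sit, the top of what this assay reports. Compound 3 is `Cc1cc(NC(=O)OCc2ccccn2)nn1Cc1cc(Cl)ccc1OCc1ccccc1`; it differs from compound 1 by (((pyridin-2-yl)methoxy)carbonyl)amino in place of benzylcarbamoyl on an aromatic carbon. The step from compound 1 is expected to run downward by a modest amount, a number at least 0.20 log units lower from compound 1 to compound 3 (that floor lies within the scatter). Compound 3 is therefore estimated at 3.5, within 2.8 to 4.2.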

Compound 3, distribution coefficient: 3.1
Compound 3: the middle estimate sits 0.40 log units above what was measured, within the range that was stated.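

At this position on the shared core, (((pyridin-2-yl)methoxy)carbonyl)amino in place of benzylcarbamoyl gives a number at least 0.60 log units lower from compound 1 to compound 3 (beyond the scatter) in this assay, so the read-out here does respond to the group on this aromatic carbon. Within the data shown here, compound 3, at 3.1, gives the first actual number. Going by these compounds, compound 1 gives only a limit, so the step is a floor and its full size stays unknown: the limit of > 3.7 in this assay, at which 2 of the 3 values shown sit.

The pyridin-2-yl ring and the carbamate enter together, so their shares of the step cannot be separated. On these data alone, how a carboxylic acid or an amine at this position would read also remains open.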